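The compounds below may be only part of what the source reports. "The series", "measured", "known", "first", "only" and "open" are said of these compounds alone.

Measured so far in a functional assay on HT-1080 cells (Homo sapiens) for cytotoxicity, read by MTT assay, with a stated time of 72 h; on this read-out higher numbers stand for weaker inhibition and lower numbers for stronger inhibition:

- compound 1, `COc1cccc(/C=C2\CCC/C(=C\c3cccc(Cl)c3)C2=O)c1OC`, gives 10300 nM
- compound 2, `COc1cccc(/C=C2\CCC/C(=C\c3cccc(OC)c3OC)C2=O)c1`, gives 9900 nM
- compound 3, `COc1cccc(/C=C2\CCC/C(=C\c3ccc(O)c(Cl)c3)C2=O)c1OC`, gives 14300 nM

All three values lie within the scatter of one another, so no order among them can be read off. The change from compound 1 to compound 2 is methoxy in place of chloro on an aromatic carbon, and it made a step of a 1.0-fold lower number from compound 1 to compound 2 (0.02 log units; within the scatter), which is within the scatter. Compound 3 differs from compound 1 by hydroxy in place of hydrogen on an aromatic carbon; that step, a 1.4-fold higher number from compound 1 to compound 3 (0.14 log units; within the scatter), is also within the scatter.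

Compound 4, `COc1cc(/C=C2\CCC/C(=C\c3cccc(OC)c3OC)C2=O)ccc1O`, is not yet measured. It differs from compound 3 by methoxy in place of chloro on an aromatic carbon. This is the same kind of change as from compound 1 to compound 2, not the same change: here the place is ortho to a hydroxy group as well as meta to a large group, whereas in compound 1 it is only meta to a large group. Because the earlier step of a 1.0-fold lower number from compound 1 to compound 2 (0.02 log units; within the scatter) was within the scatter, the step from compound 3 to compound 4 in this assay is expected to be about a 1.1-fold lower number from compound 3 to compound 4 (0.03 log units; within the scatter), likewise within the scatter. Compound 4 is therefore estimated at 13500 nM, with a range from 6000 nM to 30000 nM.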

Compound 4, half-maximal inhibitory concentration: 5900 nM
Beside the measured number, compound 4's estimate is 2.3-fold (0.36 log units) above it; measured number below the stated range.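

In this assay, methoxy in place of chloro on an aromatic carbon gives a 2.4-fold lower number from compound 3 to compound 4 (0.38 log units; beyond the scatter), but this step cannot be told apart from the same change on the core of compound 1: the same change on two cores in this assay, a 1.0-fold lower number (0.02 log units; within the scatter) from compound 1 to compound 2 and a 2.4-fold lower number (0.38 log units; beyond the scatter) from compound 3 to compound 4, 2.3-fold (0.37 log units) apart, within the scatter of two such steps. Hydroxy in place of hydrogen on an aromatic carbon gives a 1.7-fold lower number from compound 2 to compound 4 (0.22 log units; within the scatter), and its two readings are likewise not told apart: the same change on two cores in this assay, a 1.4-fold higher number (0.14 log units; within the scatter) from compound 1 to compound 3 and a 1.7-fold lower number (0.22 log units; within the scatter) from compound 2 to compound 4, 2.3-fold (0.37 log units) apart, within the scatter of two such steps. The wider replacement gives a 1.7-fold lower number from compound 1 to compound 4 (0.24 log units; within the scatter) and adds no further comparison between cores, so these pairs do not show that either change depends on the core, nor do they establish that it carries over unchanged, with each comparison resting on a single pair of steps.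

Going by these compounds, it remains open whether the step from chloro to methoxy extends to other groups at that place, such as an amine, a carboxylic acid or a longer chain like ethoxy. On these data alone, it also remains open whether the hydroxy group of 4-hydroxy-3-methoxyphenyl can give way to an amine with a similar outcome.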